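Fused thiophene guanidine hydrazones: growth inhibition notes

A few compounds are considered here, and "the series" means these few. Any claim that something is new, unique, unknown or untested is made for them only; others in the source may bear on it.

Measured so far:
compound 1 `N=C(N)N/N=C/c1c(-c2cccs2)nc2n1CCS2` — 19100 nM
compound 2 `CCOC(=O)c1nc2sc(Cl)cn2c1/C=N\NC(=N)N` — 19500 nM
compound 3 `Cc1cc(-c2nc3sc(C)cn3c2/C=N/NC(=N)N)c(C)s1` — 8320 nM

In a functional assay on cells (Cancer cell lines, Homo sapiens) for inhibition (a higher number here means a weaker inhibitor of growth, a lower number a stronger inhibitor of growth), compound 1 gives 19100 nM, the second highest of the three numbers. Compound 2 lies within the scatter of compound 1, so no order between them can be read. Going by the values given here, compound 3 gives a lower number than compound 1, and that gap lies beyond the scatter; compound 3 carries a dimethyl-substituted thiophene where compound 1 carries thiophen-2-yl, but no single-change step between measured compounds is known, so this is only what two values show.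

Compound 4 `N=C(N)N/N=C/c1c(-c2cc(Cl)sc2Cl)nc2n1CCS2` differs from compound 1 in one place: 2,5-dichlorothiophen-3-yl in place of thiophen-2-yl on an aromatic carbon. Two chlorine atoms enter on the thiophene ring and the ring attaches through a different carbon. Among the compounds with values here, no measured pair isolates such a change. Compound 3 shows that a substituted thiophene can go with a lower number, so a modest downward step is expected from compound 1 to compound 4 in this assay, estimated as a 1.6-fold lower number from compound 1 to compound 4 (0.20 log units; within the scatter), though a change no larger than the scatter would not be surprising. For compound 4 the expected value in this assay is 12000 nM, within 4000 nM to 35000 nM.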

Compound 4, concentration for 50% growth inhibition: 8710 nM
The estimate for compound 4 lay 1.4-fold (0.14 log units) above the measured number, and the stated range covers the measured number.
By their numbers in this assay, from the lowest: compounds 3 and 4 (each within the scatter of the next); then compounds 1 and 2 (each within the scatter of the next).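

In this assay, going by these compounds alone, 2,5-dichlorothiophen-3-yl in place of thiophen-2-yl on this aromatic carbon gives a 2.2-fold lower number from compound 1 to compound 4 (0.34 log units; beyond the scatter), the only single-change step available so far. This position, on the five-membered aromatic ring with 2 nitrogen, therefore accepts a heavier thiophene carrying two chlorine atoms and attached through a different carbon, with no loss of growth inhibition. No measurement at hand explains the lower number.

The step combines the entry of the chlorine atoms with the change of attachment carbon, and the compounds shown cannot separate the two. Also open, from the compounds shown here alone, is how a simple phenyl ring, an amine or a carboxylic acid at this position would read in this assay.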